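The source may report more compounds than this note shows. Statements on the series, on what has been measured and on what is new or still open speak of the compounds shown alone.

Measured so far in a physicochemical assay for solubility, using the shake flask method, at pH 7.4; on this read-out higher numbers stand for higher solubility and lower numbers for lower solubility:
- compound 1 `CC(C)(C)OC(=O)N[C@H]1CCCCC/C=C\[C@@H]2C[C@@]2(C(=O)NS(=O)(=O)C2CC2)NC(=O)[C@@H]2C[C@@H](OC(=O)N3CCc4ccccc4C3)CN2C1=O`: > 1000 ug/mL (a limit of the assay)
- compound 2 `CC(C)(C)OC(=O)N[C@H]1CCCCC/C=C\[C@@H]2C[C@@]2(C(=O)NS(=O)(=O)C2CC2)NC(=O)[C@@H]2C[C@@H](OC(=O)N3Cc4ccccc4C3)CN2C1=O`: > 1000 ug/mL (a limit of the assay)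

Compound 2 has no numerical value in this assay: its > 1000 ug/mL is a limit of the assay. Compound 1 shares that limit, so the evidence amounts to the limit of > 1000 ug/mL in this assay, at which 2 of the 2 values shown sit.

Compound 3 `CN(C)S(=O)(=O)NC(=O)[C@@]12C[C@H]1/C=C\CCCCC[C@H](NC(=O)OC(C)(C)C)C(=O)N1C[C@H](OC(=O)N3Cc4ccccc4C3)C[C@H]1C(=O)N2` differs from compound 2 by dimethylamino in place of cyclopropyl on a sulfonyl sulfur. In words, dimethylamino stands in place of cyclopropyl on a sulfonyl sulfur.

Among the compounds with values here, only one measured step is available, a step that the two limits leave unreadable from compound 1 to compound 2. It involves a different change, on a carbonyl carbon, and gives no size to carry over. Within the data shown here, no measured step covers the exchange on the sulfonyl sulfur.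

The expectation therefore rests on compound 2 alone, with its limit of > 1000 ug/mL, and no shift beyond the scatter is predicted in either direction. The expected step is a number no higher from compound 2 to compound 3 (the limit leaves the size open). A reading at the limit of the assay is the most likely outcome.

For compound 3 the estimate is 1000 ug/mL, with an expected range of 400 ug/mL to 2000 ug/mL.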

Compound 3, solubility: > 1000 ug/mL
Compound 3: only a limit was reported (the forecaster's own chance of this, stated with the estimate: 75%); the middle value sits exactly at the limit.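

Compound 2 and compound 3 both report only a limit of the assay in this assay and so no step can be read for dimethylamino in place of cyclopropyl on a sulfonyl sulfur. Left open is how far compound 1, compound 2 and compound 3 differ in this assay if at all, with every value at one limit: the limit of > 1000 ug/mL in this assay, at which 3 of the 3 values shown sit.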